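Methyl on the acetoxy chain carbon: cell-growth notes

The source may hold more compounds than are shown below. What is called first, only, known or untested is meant among the compounds shown, and "the series" means these compounds.

Compound 1 `COc1ccc(C(=O)/C(=C/C2CCCCC2)CCOC(C)=O)cc1` and compound 3 `COc1ccc(C(=O)/C(=C/C2CCCCC2)CC(C)OC(C)=O)cc1` share one core; compound 2 `COc1ccc(C(=O)/C(=C/c2c(F)c(F)c(F)c(F)c2F)CCOC(C)=O)cc1` and compound 4 `COc1ccc(C(=O)/C(=C/c2c(F)c(F)c(F)c(F)c2F)CC(C)OC(C)=O)cc1` share another. How the two cores differ is not broken down here. In a functional assay on A549 cells (Homo sapiens) for inhibition, read by XTT assay, with a stated time of 48 h (a lower number here means a stronger inhibitor, a higher number a weaker inhibitor), compound 1 returns only a limit of the assay, > 100000 nM (the limit of > 100000 nM in this assay, at which 1 of the 3 values shown sits). In this assay compound 3 gives 98000 nM and compound 2 gives 58100 nM. The change methyl in place of hydrogen on a saturated chain carbon bound to an oxygen next to a carbonyl group and a saturated chain carbon gives the step of an at least 1.0-fold lower number from compound 1 to compound 3 (0.00 log units; that floor lies within the scatter). The same change, (methyl in place of hydrogen on a saturated chain carbon bound to an oxygen next to a carbonyl group and a saturated chain carbon), carries compound 2 to compound 4 and is not yet measured. The step is expected to be about a 1.1-fold lower number from compound 2 to compound 4 (0.02 log units; within the scatter), resting on the flat step seen for compound 1 to compound 3 an at least 1.0-fold lower number from compound 1 to compound 3 (0.00 log units; that floor lies within the scatter). Compound 4 is thus estimated at 55000 nM, between 25000 nM and 120000 nM.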

Compound 4, half-maximal inhibitory concentration: 91700 nM
Beside the measured number, compound 4's estimate is 1.7-fold (0.22 log units) below it; low and high end bracket the measured number.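

In this assay, methyl in place of hydrogen on the core of compound 2 gives a 1.6-fold higher number from compound 2 to compound 4 (0.20 log units; within the scatter), so on this core the change does not move the number beyond the scatter. Compound 1 gives > 100000 nM, a limit of the assay and not a number, and the size of the step on its core cannot be read. The two steps therefore show neither that the change carries from one core to the other nor that it fails to: the same change on two cores in this assay, an at least 1.0-fold lower number (0.00 log units; that floor lies within the scatter) from compound 1 to compound 3 and a 1.6-fold higher number (0.20 log units; within the scatter) from compound 2 to compound 4; the limit leaves it open whether they differ

The compounds shown leave open what an ethyl group or a longer chain would do in place of the methyl, or an amine in place of the acetoxy group. Also open, on these data alone, is how the same change behaves on a core whose values all lie clear of the limit in this assay.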